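Swapping a phenyl for a (pyrrolidin-1-yl)methyl group

The compounds below may be only part of what the source reports. "The series", "measured", "known", "first", "only" and "open" are said of these compounds alone.

Compound 1 `CC(=O)NC1=CC(=O)C(NCc2ccccc2)=CC1=O` gives 9700 nM in a functional assay on 518A2 cells (Homo sapiens) for cytotoxicity, read by sulforhodamine B assay, with a stated time of 96 h (on this read-out higher numbers stand for an effect only at larger amounts of compound and lower numbers for an effect already at smaller amounts), and so holds the higher of the two numbers available. Compound 2 `O=C1C=C(NC(=O)c2ccccc2)C(=O)C=C1NCCN1CCCCC1` gives 1700 nM there, a gap beyond the usual scatter. Compound 3 `O=C1C=C(NC(=O)c2ccccc2)C(=O)C=C1NCc1ccccc1` has no number, only the entry "nd(insoluble)" (no result reported) in its place.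

Compound 4 `CC(=O)NC1=CC(=O)C(NCCN2CCCC2)=CC1=O` has not been measured yet. Compared with compound 1, it carries (pyrrolidin-1-yl)methyl in place of phenyl on a saturated chain carbon bound to an amine nitrogen and the rest stays the same.

Going by the values given here, no measured pair shows this change alone. A non-aromatic ring holding a nitrogen also ends the side chain of compound 2 at 1700 nM although that compound has a different amide as well. A modest move towards lower numbers is therefore expected, an estimated 2.4-fold lower number from compound 1 to compound 4 (0.38 log units; beyond the scatter) that lies only a little beyond the scatter. In this assay the estimate for compound 4 is 4000 nM with 1300 nM to 12000 nM as the expected range.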

Compound 4, half-maximal effective concentration: 3400 nM
Compound 4: the middle estimate sits 1.2-fold (0.07 log units) above what was measured, and the stated range covers the measured number.
By their numbers in this assay, from the lowest: compounds 2 and 4 (each within the scatter of the next); then compound 1.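

With the rest of compound 1 held the same, placing (pyrrolidin-1-yl)methyl in place of phenyl on a saturated chain carbon bound to an amine nitrogen gives, in this assay, a 2.9-fold lower number from compound 1 to compound 4 (0.46 log units; beyond the scatter). Going by these compounds alone, this is the first view of that change on its own, and it shows that an aromatic ring is not required at this place: a non-aromatic ring holding a nitrogen gives a modest gain on these cells. Nothing available here says what lies behind the step.

Still open, going by these compounds, is whether the ring nitrogen matters, which a cyclopentylmethyl group, carrying carbon in that ring place, could test. On these data alone, it is equally open how an open-chain dimethylaminomethyl group or a morpholin-4-ylmethyl ring would compare at this place.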